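Hydrogen in place of trifluoromethyl in compound 2

The compounds below may be only part of what the source reports. "The series", "measured", "known", "first", "only" and "open" are said of these compounds alone.

Measured so far in a functional assay on the whole organism with Mus musculus as the target; on this read-out higher numbers stand for an effect only at larger amounts of compound and lower numbers for an effect already at smaller amounts:
Compound 1 `Fc1ccc(-c2n[nH]c(S)n2)cc1` gives > 200 mg/kg as a limit
Compound 2 `Cn1nc(-c2cccc(C(F)(F)F)c2)n(C)c1=S` gives > 200 mg/kg as a limit
Compound 3 `Cn1nc(-c2c(Cl)cccc2Cl)n(C)c1=S` gives > 100 mg/kg as a limit

None of these three compounds has yet given an exact number. Compound 2 stands at the limit of > 200 mg/kg in this assay, at which 2 of the 3 values shown sit, and so has no exact place on the scale. Compound 3 stands at the limit of > 100 mg/kg in this assay, at which 1 of the 3 values shown sits, and that too is only a limit.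

Compound 4 `Cn1nc(-c2ccccc2)n(C)c1=S` keeps the core of compound 2 but has hydrogen in place of trifluoromethyl on an aromatic carbon, as counted in hydrogen in place of trifluoromethyl on an aromatic carbon and it has not yet been measured. Among the measured compounds shown here, no measured pair shows what such a change does, so any forecast here is uncertain. An effect at smaller doses is expected, with an estimated at least 3.3-fold lower number from compound 2 to compound 4 (0.52 log units; beyond the scatter) that would lie beyond the usual scatter. Another limit would remain possible. For compound 4 the expected value is 60 mg/kg with an estimated range from 20 mg/kg to 200 mg/kg as the likely span.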

Compound 4, dose for half-maximal effect: 0.13 mg/kg
Beside the measured number, compound 4's estimate is 460-fold (2.66 log units) above it; the whole stated range lies above it.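

In this assay, among the compounds shown here, the earlier compounds gave only limits, and compound 4 is the first to give an exact number, so it shows that the shared core can act at small doses. Hydrogen in place of trifluoromethyl on an aromatic carbon gives an at least 1500-fold lower number from compound 2 to compound 4 (3.18 log units; beyond the scatter), so in this pair a single place on the ring carries a very large effect. Compound 2 itself is held only by a limit: the limit of > 200 mg/kg in this assay, at which 2 of the 4 values shown sit.

On these data alone, what a methoxy group, a chlorine or an amine at this same place would give stays open, and so does whether any group there is tolerated at all. As far as these compounds go, compound 1 differs from compound 4 in more than one place, so the part played by the methyl groups on the core also remains open.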